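The source may hold more compounds than are shown below. What is called first, only, known or untested is meant among the compounds shown, and "the series" means these compounds.

Compound 1 `N#Cc1ccc(N2CCCc3c(-c4cccnc4)cccc32)cc1C(F)(F)F` gives 13500 nM in a functional assay on VCaP cells (Homo sapiens) for antiproliferative activity, read by CCK-8 assay, with a stated time of 6 days; a lower number here means a stronger inhibitor, a higher number a weaker inhibitor.
Compound 2 `CCN(c1ccc(C#N)c(Cl)c1)c1cc(-c2cccs2)ccc1C` gives "not determined" (no result reported) in this assay.
Compound 3 `N#Cc1ccc(N2CCc3cc(-c4cncnc4)ccc3C2)cc1C(F)(F)F` gives "not determined" (no result reported) in this assay.

Within the data shown here, the only number so far belongs to compound 1, and it marks a weak inhibitor. Compound 2 stands without a number: its result in this assay is not reported, and compound 3 is in the same position, so there is nothing to rank compound 2 against. Compound 4 `CCN(c1ccc(C#N)c(Cl)c1)c1cc(-c2ccncc2)ccc1C` is built on the shared core of compound 2 and differs from it in one place (pyridin-4-yl in place of thiophen-2-yl on an aromatic carbon). Among the measured compounds shown here, no step between two measured compounds is available to set the size of this change, so any expectation rests on compound 1, whose 13500 nM marks weak inhibition. For compound 4 a result in this assay near 3000 nM is expected, plausibly between 400 nM and 20000 nM.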

Compound 4, half-maximal inhibitory concentration: 2900 nM
Compound 4: the middle estimate sits 1.0-fold (0.01 log units) above what was measured; measured number inside the range.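

Compound 2 has no single number in this assay, so no step can be read between compound 2 and compound 4. Going by these compounds, what pyridin-4-yl in place of thiophen-2-yl does to activity stays open, and no other evidence here bears on it.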